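The source may report more compounds than this note shows. Statements on the series, on what has been measured and on what is new or still open speak of the compounds shown alone.

The measured compounds, each in a functional assay on MGC-803 cells (Homo sapiens) for cytotoxicity, read by MTT assay, with a stated time of 48 h; on this read-out lower numbers stand for stronger inhibition and higher numbers for weaker inhibition:

Compound 1, `CC1=NN(C(=O)CN2CCN(C(=O)OC(C)(C)C)CC2)C(c2ccccc2O)C1`: in this assay compound 1 gives 17600 nM.
Compound 2, `CCN(CC)CC(=O)N1N=C(C)CC1c1ccccc1OC(C)=O`: in this assay compound 2 gives 29500 nM.
Compound 3, `O=C(c1ccccc1)N1N=C(c2cc3ccccc3oc2=O)CC1c1ccccc1`: in this assay compound 3 gives 12700 nM.

Compound 3 has the smallest of the three numbers. Its gap to compound 1 lies within the usual scatter of repeated measurements, so those two cannot be put in order on these data. Compound 2 stands beyond the scatter, with the larger number, so on this read-out it inhibits the cells less than compound 3.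

Compound 4, `CCC(=O)N1N=C(c2cc3ccccc3oc2=O)CC1c1ccccc1`, differs from compound 3 in a single place: ethyl in place of phenyl on a carbonyl carbon. Among the measured compounds shown here, no pair of measured compounds shows this same change, so there is no measured step that tells how large an effect to expect. The three measured compounds have different cores, and each carries a different group on the ring nitrogen, which makes none of them a clean guide either.

The expectation is therefore cautious: a step of modest size, if any, most likely toward a somewhat higher number, but possibly none beyond the scatter. The step expected from compound 3 to compound 4, a 1.4-fold higher number from compound 3 to compound 4 (0.15 log units; within the scatter), is small. For compound 4 the estimated value in this assay is 18000 nM, with a range from 6000 nM to 55000 nM.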

Compound 4, half-maximal inhibitory concentration: 5300 nM
Beside the measured number, compound 4's estimate is 3.4-fold (0.53 log units) above it; measured number below the stated range.
By their numbers in this assay, from the lowest: compound 4; then compounds 3, 1 and 2 (each within the scatter of the next, the first and the last beyond it).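

On the carbonyl carbon attached to the ring's amide-type nitrogen, putting ethyl in place of phenyl gives a 2.4-fold lower number from compound 3 to compound 4 (0.38 log units; beyond the scatter) in this assay. Among the compounds shown here, this is the first single-place step in the set, and it shows that this position can change the number beyond the usual scatter and that, in this pair, the benzoyl group's aromatic ring is not required for inhibition of these cells: the smaller propanoyl group, with 2 heavy atoms in place of 6 in the exchanged part, gives the lower number. No measurement shown here explains why the number falls with this change.

One step cannot separate the loss of the aromatic ring from the drop in size, and a cyclohexyl group on the same carbonyl carbon would help to tell those two apart. Methyl, or a longer chain such as propyl or butyl, would show whether the number keeps falling as the group shrinks or has a best length, while a dimethylamino group would test whether a carbon chain is needed here at all.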